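A Bromo Added to Compound 2

A few compounds are considered here, and "the series" means these few. Any claim that something is new, unique, unknown or untested is made for them only; others in the source may bear on it.

In a functional assay on A549 cells (Homo sapiens) for cytotoxicity (on this read-out lower numbers stand for an effect already at smaller amounts and higher numbers for an effect only at larger amounts of compound), compound 1 `COC1=C(C)C(=O)/C(=C(O)/C=C/c2cc(C)cc(C)c2)C(=O)C1(C)C` gives 4.3 ug/mL and compound 2 `CCCC1=C(OC)C(CCC)(CCC)C(=O)/C(=C(O)\C=C\c2ccccc2)C1=O` gives 1.4 ug/mL so far. Compound 2 therefore holds the lower of the two numbers, and the gap between them lies beyond the usual scatter of repeated measurements. The two compounds differ in more than one place, so their gap cannot be tied to any single group.

Compound 3 `CCCC1=C(OC)C(CCC)(CCC)C(=O)/C(=C(O)\C=C\c2ccc(Br)cc2)C1=O` changes compound 2 in just one place, with bromo in place of hydrogen on an aromatic carbon. Among the measured compounds shown here, no measured pair shows what this swap does. Starting from compound 2 at 1.4 ug/mL only a small shift toward a lower number is expected, inside the scatter. The estimated step is a 1.2-fold lower number from compound 2 to compound 3 (0.07 log units; within the scatter) and no more than that is expected. Compound 3 is estimated at 1.2 ug/mL with a range from 0.5 ug/mL to 3 ug/mL expected to hold the measurement.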

Compound 3, concentration for half-maximal effect: 1 ug/mL
Beside the measured number, compound 3's estimate is 1.2-fold (0.08 log units) above it; the measured number falls inside the stated range.
By their numbers in this assay, from the lowest: compounds 3 and 2 (each within the scatter of the next); then compound 1.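

In this assay, among the compounds shown here, the swap of hydrogen for bromo gives the first reading of a single change, a 1.4-fold lower number from compound 2 to compound 3 (0.15 log units; within the scatter) on the scale of that assay. At this place, on an aromatic carbon para to a large group, the phenyl of compound 2 can therefore become the 4-bromophenyl of compound 3 with no change that stands out from the scatter of repeated measurements, something the comparison with compound 1 could not show, as it differs from compound 2 in more than one place. No separate measurement is available that would explain this result.

Still open, on these data alone, is how an amine or a carboxylic acid would read at this same place on the ring. As far as these compounds go, it is also open whether bromo on a different aromatic carbon would stay as close to compound 2, and whether a single bromo reading says anything about other halogens such as chlorine or fluorine.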